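Side-chain series: the dimethylamino to methyl step

This account rests on a few compounds, and the source may have more. Where it says the series, first, only, none or still open, it means among the compounds named here.

compound 1 `COc1ncc(-c2ccc3nc(NC(=O)NCCN4CCCC4)nn3c2)cc1NS(=O)(=O)c1ccc(F)cc1` gives 230 nM
compound 2 `COc1ncc(-c2ccc3nc(NC(=O)NCC(=O)N4CCCC4)nn3c2)cc1NS(=O)(=O)c1ccc(F)cc1` gives 140 nM
compound 3 `COc1ncc(-c2ccc3nc(NC(=O)NCCN(C)C)nn3c2)cc1NS(=O)(=O)c1ccc(F)cc1` gives 220 nM
compound 4 `CCCNC(=O)Nc1nc2ccc(-c3cnc(OC)c(NS(=O)(=O)c4ccc(F)cc4)c3)cn2n1` is not yet measured

All values come from a functional assay on HCT-116 cells (Homo sapiens) for cytotoxicity, read by MTT assay, with a stated time of 72 h; on this read-out higher numbers stand for weaker inhibition and lower numbers for stronger inhibition. Compound 3 stands within the scatter of both other measured compounds, with a 1.0-fold lower number from compound 1 to compound 3 (0.02 log units; within the scatter) and a 1.6-fold higher number from compound 2 to compound 3 (0.20 log units; within the scatter). The next change is methyl in place of dimethylamino on a saturated chain carbon, two bonds along the chain from an amide-type nitrogen. Within the data shown here, no measured step makes this exact replacement. The nearest evidence is a 1.0-fold lower number from compound 1 to compound 3 (0.02 log units; within the scatter), together with a 1.6-fold lower number from compound 1 to compound 2 (0.22 log units; within the scatter). On that basis, no step beyond the scatter is expected in this assay. The estimated step is a 1.2-fold lower number from compound 3 to compound 4 (0.06 log units; within the scatter). Compound 4 is expected at 190 nM, within an estimated range of 85 nM to 420 nM.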

Compound 4, half-maximal inhibitory concentration: 150 nM
For compound 4 the middle estimate is 1.3-fold (0.10 log units) above the measured one; the measured number falls inside the stated range.
By their numbers in this assay, from the lowest: compounds 2, 4, 3 and 1 (each within the scatter of the next).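

Methyl in place of dimethylamino on a saturated chain carbon, two bonds along the chain from an amide-type nitrogen, gives no step beyond the scatter in this assay: a 1.5-fold lower number from compound 3 to compound 4 (0.17 log units; within the scatter). The same holds for methyl in place of pyrrolidin-1-yl, a 1.5-fold lower number from compound 1 to compound 4 (0.19 log units; within the scatter), and for ethyl in place of (pyrrolidin-1-yl)carbonyl, a 1.1-fold higher number from compound 2 to compound 4 (0.03 log units; within the scatter). The propyl chain, which carries no amine, therefore reads like the three chains that do carry a nitrogen group, and no measurement at hand explains this. On these data alone, whether a carboxylic acid or a longer chain at this position would give a step beyond the scatter remains open.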